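The source may report more compounds than this note shows. Statements on the series, on what has been measured and on what is new or still open speak of the compounds shown alone.

Values so far in a functional assay on MCF7 cells (Homo sapiens) for cytotoxicity, read by MTT assay, with a stated time of 24 h (a higher number here means a weaker inhibitor, a lower number a stronger inhibitor), are these:

- compound 1 `O=C(NC(=S)Nc1nc2ccccc2s1)c1ccccc1` gives 37300 nM
- compound 2 `O=C(NC(=S)Nc1nc2cc([N+](=O)[O-])ccc2s1)N1CCOCC1` gives 31000 nM
- compound 3 `Nc1ccc2sc(NC(=S)NC(=O)N3CCOCC3)nc2c1` gives 26400 nM

Compound 3 stands level with the other two. Compound 1 and compound 2 both lie within the usual scatter of it, so these numbers give no ranking.

The next compound is compound 4 `O=C(NC(=S)Nc1nc2ccccc2s1)N1CCOCC1`, which has not yet been measured. It differs from compound 3 in one place: hydrogen in place of amino on an aromatic carbon gives hydrogen in place of amino on an aromatic carbon.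

Within the data shown here, one measured step bears directly on this place. It is a 1.2-fold lower number from compound 2 to compound 3 (0.07 log units; within the scatter) for amino in place of nitro, a small change in the number. Compound 1 also carries hydrogen at this place, though it differs from compound 4 elsewhere, and compound 1 gives 37300 nM as its value, close to the others. Among the measured compounds shown here, this is thin evidence, since no measured step removes the amino group itself.

Resting on a 1.2-fold lower number from compound 2 to compound 3 (0.07 log units; within the scatter) as the only guide, no step beyond the scatter is expected in this assay here. The estimated change is a 1.1-fold higher number from compound 3 to compound 4 (0.06 log units; within the scatter) in size. The estimate for compound 4 is 30000 nM as the middle, with an expected range from 15000 nM to 60000 nM around it.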

Compound 4, half-maximal inhibitory concentration: 29300 nM
Estimate against measurement, compound 4: 1.0-fold (0.01 log units) above, within the range that was stated.
By their numbers in this assay, from the lowest: compounds 3, 4, 2 and 1 (each within the scatter of the next).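

In this assay the aromatic carbon that carried amino or nitro can also carry plain hydrogen with no step beyond the scatter, as shown by hydrogen in place of amino (a 1.1-fold higher number from compound 3 to compound 4 (0.05 log units; within the scatter)) and hydrogen in place of nitro (a 1.1-fold lower number from compound 2 to compound 4 (0.02 log units; within the scatter)), so compound 2, compound 3 and compound 4 stand level and the group at this place need not be there for the cytotoxic effect seen at these values. Among these compounds, compound 4 also gives the first direct comparison at the carbonyl carbon, where morpholin-4-yl in place of phenyl (a 1.3-fold lower number from compound 1 to compound 4 (0.10 log units; within the scatter)) likewise stays within the scatter, so this pair gives no ranking of those two groups. Nothing measured alongside these compounds offers an explanation for these level values.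

From the compounds shown here alone, only hydrogen, amino and nitro have been compared at the aromatic carbon, so it remains open whether a group such as methoxy, chlorine or a carboxylic acid there would stand level too. At the carbonyl carbon, only morpholin-4-yl and phenyl can be compared, which leaves open what a dimethylamino group or a longer alkyl chain would give.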